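The source may hold more compounds than are shown below. What is called first, only, known or untested is meant among the compounds shown, and "the series" means these compounds.

Compound 1 `Cc1cc(C)c(S(=O)(=O)N2CCC(N3CCC(C)CC3)CC2)c(C)c1`: 0.03 nM
Compound 2 `Cc1cc(C)c(S(=O)(=O)N2CCC(N3CCCCC3)CC2)c(C)c1`: 2200 nM

Both compounds were tested in a functional assay on DLD-1 cells (Homo sapiens) for antiproliferative activity, read by CellTiter-Glo, with a stated time of 72 h; on this read-out lower numbers stand for stronger inhibition and higher numbers for weaker inhibition. Among the compounds with values here, compound 2 holds the highest of the two numbers; its nearest neighbour is compound 1, and the step of a 73000-fold higher number from compound 1 to compound 2 (4.87 log units; beyond the scatter) is the only step measured here. That step rests on one change: hydrogen in place of methyl on a saturated ring carbon.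

Compound 3 `Cc1cc(C)c(S(=O)(=O)N2CCC(C3OCC(C)CO3)CC2)c(C)c1` has not yet been measured. It differs from compound 2 by a group of 7 heavy atoms (5 carbon, 2 oxygen; one six-membered non-aromatic ring with 2 hetero atoms) in place of a group of 6 heavy atoms (5 carbon, 1 nitrogen; one six-membered non-aromatic ring with 1 hetero atom), on a saturated ring carbon. The measured step bears on this only in part: it shows that a methyl on a saturated ring carbon of this side group can move the number a great deal, and the ring that enters in compound 3 carries such a methyl. Within the data shown here, no measured step shows what exchanging the ring itself does, so the data leave the direction open. A lower number than that of compound 2 is expected, with a wide range, because a single methyl produced a 73000-fold higher number from compound 1 to compound 2 (4.87 log units; beyond the scatter). Compound 3 is therefore estimated at 300 nM, between 10 nM and 5000 nM. That expected change amounts to a 7.3-fold lower number from compound 2 to compound 3 (0.87 log units; beyond the scatter).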

Compound 3, half-maximal inhibitory concentration: > 5000 nM
Compound 3 gave a limit, no number (the forecaster's own chance of this, stated with the estimate: 10%); middle value at least 16-fold (1.22 log units) away from the limit.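

In this assay compound 3 gave a limit of the assay and not a number: the limit of > 5000 nM in this assay, at which 1 of the 3 values shown sits. Placing the new ring with two oxygens on this saturated ring carbon, in place of piperidin-1-yl, gives an at least 2.2-fold higher number from compound 2 to compound 3 (0.35 log units; beyond the scatter), so the methyl carried by the entering ring does not bring this compound anywhere near compound 1. The comparison with the methyl-bearing ring that contains nitrogen gives an at least 160000-fold higher number from compound 1 to compound 3 (5.22 log units; beyond the scatter), which shows that in these three compounds a methyl on the side ring is not enough by itself: the very low number appears only when that methyl sits on the nitrogen-containing ring of compound 1.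

From the compounds shown here alone, how far beyond its limit compound 3 lies remains unknown, and these compounds cannot separate the loss of the ring nitrogen from the gain of the two ring oxygens. They also leave open whether a morpholine ring, or an ethyl group in place of the methyl on the ring of compound 1, would keep any of that strong inhibition.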